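The compounds below may be only part of what the source reports. "The series", "measured", "known", "first", "only" and "open" are said of these compounds alone.

Going by the values given here, compound 3, `O=c1n(Cc2nc(-c3cccnc3)cn2CCCCO)c2cnccc2n1C1CC1`, gives 1.2 in a physicochemical assay for lipophilicity, measured as octanol-water partition, at pH 7.4 (on this read-out higher numbers stand for higher lipophilicity and lower numbers for lower lipophilicity), and stands lowest of the three numbers known so far. Compound 2, `CC(C)n1nc(Cn2c(=O)c3ccccc3n2CCCCO)c2ccccc21`, gives 2.9 in this assay, beyond the scatter above compound 3, and compound 1, `CC(C)n1nc(Cn2nc3ccccc3c2CCCO)c2ccccc21`, gives 3.8, further above again. Compound 4, `O=c1n(Cc2nc(-c3ccccn3)cn2CCCCO)c2cnccc2n1C1CC1`, has not yet been measured. It differs from compound 3 in one place: pyridin-2-yl in place of pyridin-3-yl on an aromatic carbon. No pair of measured compounds isolates a swap of this kind, so its size cannot be read from the numbers shown. The expected step of a number 0.20 log units higher from compound 3 to compound 4 (within the scatter) is small, if anything slightly upward, and stays within the scatter. Compound 4 is therefore expected to give about 1.4 in this assay, with a range from 0.9 to 1.9.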

Compound 4, distribution coefficient: 1.4
Compound 4: middle estimate and measured number agree at the digits printed; the range from low to high includes it.
By their numbers in this assay, from the lowest: compounds 3 and 4 (each within the scatter of the next); then compound 2; then compound 1.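

With pyridin-2-yl in place of pyridin-3-yl on the aromatic carbon, this assay gives a number 0.20 log units higher from compound 3 to compound 4 (within the scatter), the first step shown in which this position alone changes. For this pair, which has the same atoms joined differently, the two pyridinyl groups cannot be told apart on this read-out. Nothing shown bears on the reason for this result. From the compounds shown here alone, what pyridin-4-yl, phenyl or a carboxylic acid would give on this carbon remains open. So does whether the swap would give a similar step with a chain other than the 4-hydroxybutyl group on the neighbouring ring nitrogen.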